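The source may hold more compounds than are shown below. What is called first, only, known or untested is meant among the compounds shown, and "the series" means these compounds.

Measured compounds:
Compound 1, `CCC(=O)N1c2ccccc2CCC1C(=O)Nc1ccccc1C(F)(F)F`. In a functional assay on HCT-15 cells (Homo sapiens) for cytotoxicity, read by sulforhodamine B assay, with a stated time of 72 h (on this read-out lower numbers stand for stronger inhibition of growth and higher numbers for weaker inhibition of growth), compound 1 gives only a limit of the assay, > 80000 nM.
Compound 2, `O=C(Nc1ccccc1C(F)(F)F)C1CCc2ccccc2N1C(=O)c1ccccc1`. In this assay compound 2 gives 6500 nM.

Going by the values given here, compound 2 therefore holds the only number in this assay; compound 1 sits at a limit, as noted in the limit of > 80000 nM in this assay, at which 1 of the 2 values shown sits. Among the compounds with values here, the single measured step, phenyl in place of ethyl on a carbonyl carbon, gives an at least 12-fold lower number from compound 1 to compound 2 (1.09 log units; beyond the scatter), a large change that is read against a limit rather than a number.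

Compound 3, `O=C(Nc1ccccc1C(F)(F)F)C1CCc2ccccc2N1C(=O)c1ccc(Cl)cc1`, differs from compound 2 by chloro in place of hydrogen on an aromatic carbon. Within the data shown here, no measured step concerns a substituent on that benzoyl ring; the measured step exchanges the whole group on the carbonyl carbon and so does not bear directly on adding a chloro to it. Among the measured compounds shown here, with no step of this kind to draw on, no change beyond the scatter in this assay is expected, in either direction.

Compound 3 is thus estimated at 5000 nM, with a range from 1500 nM to 15000 nM. That estimate means a step of a 1.3-fold lower number from compound 2 to compound 3 (0.11 log units; within the scatter), which is expected to stay within the scatter.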

Compound 3, concentration for 50% growth inhibition: 839 nM
Compound 3: the middle estimate sits 6.0-fold (0.78 log units) above what was measured, and the stated range ends above it.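

In this assay, the benzoyl ring proves responsive to a single-atom change: chloro in place of hydrogen on an aromatic carbon, para to a large group, gives a 7.7-fold lower number from compound 2 to compound 3 (0.89 log units; beyond the scatter). Going by these compounds alone, this is the first measured change made on that ring itself, and it shows that activity here does not depend only on exchanging the whole group on the carbonyl carbon. Exchanging ethyl for 4-chlorophenyl on that carbonyl carbon gives an at least 95-fold lower number from compound 1 to compound 3 (1.97 log units; beyond the scatter), a step read against a limit and not a number: the limit of > 80000 nM in this assay, at which 1 of the 3 values shown sits.

The compounds shown carry only chloro on the benzoyl ring and only at this one place, so they leave open whether fluoro, methoxy or a nitrile there would give a similar step, and whether chloro at another place on the ring would do the same. They also leave open how far the shared core tolerates changes elsewhere, such as an amine or a carboxylic acid in place of the trifluoromethyl group, or a longer chain in place of ethyl on the carbonyl carbon.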